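The compounds below may be only part of what the source reports. "The series", "measured", "known", "first", "only" and "open" are said of these compounds alone.

Compound 1 `CCS(=O)(=O)Nc1cc(-c2ccc3ncnc(Nc4ccc(F)cc4F)c3c2)cnc1OC` and compound 2 `CCS(=O)(=O)Nc1cc(-c2ccc3ncnc(Nc4ccc(F)c(C(=O)OC)c4)c3c2)cnc1OC` share one core and differ only in the aryl ring on the amine nitrogen. In a functional assay on HCT-116 cells (Homo sapiens) for cytotoxicity, read by sulforhodamine B assay, with a stated time of 72 h (a higher number here means a weaker inhibitor, a lower number a stronger inhibitor), compound 1 gives 4010 nM, and compound 2 gives 2360 nM. Of the two numbers compound 2 carries the lower one, yet the step of a 1.7-fold lower number from compound 1 to compound 2 (0.23 log units; within the scatter) lies within the scatter, so the two compounds sit together rather than apart. Compound 3 `CCS(=O)(=O)Nc1cc(-c2ccc3ncnc(Nc4ccc(Cl)c(C(=O)OC)c4)c3c2)cnc1OC` differs from compound 2 by chloro in place of fluoro on an aromatic carbon. Among the measured compounds shown here, no measured step touches this position: the single step at hand, a 1.7-fold lower number from compound 1 to compound 2 (0.23 log units; within the scatter), exchanges the whole aryl ring and is itself within the scatter, so it offers no direction for a single halogen swap. The expectation is therefore a step no larger than the scatter, a 1.2-fold lower number from compound 2 to compound 3 (0.07 log units; within the scatter), in this assay. Compound 3 is estimated at 2000 nM in this assay, with a range from 800 nM to 5000 nM.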

Compound 3, half-maximal inhibitory concentration: 3130 nM
The estimate for compound 3 lay 1.6-fold (0.19 log units) below the measured number; measured number inside the range.
By their numbers in this assay, from the lowest: compounds 2, 3 and 1 (each within the scatter of the next).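

On the aromatic carbon ortho to a methoxycarbonyl group, chloro in place of fluoro gives a 1.3-fold higher number from compound 2 to compound 3 (0.12 log units; within the scatter) in this assay. Among the compounds shown here, this is the first reading of a single-atom exchange at this position, and it does not separate the two compounds. The wider exchange reads the same way, with a 1.3-fold lower number from compound 1 to compound 3 (0.11 log units; within the scatter), so 4-chloro-3-(methoxycarbonyl)phenyl stays with 2,4-difluorophenyl, as 4-fluoro-3-(methoxycarbonyl)phenyl does, and no measurement at hand bears on why these steps are so small.

On these data alone, the three compounds sit together, so it remains open whether this position can shift the number beyond the scatter at all. An amine or a longer chain in place of the halogen, or a carboxylic acid in place of the methoxycarbonyl group, would be the kind of exchange that could answer this.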